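This account rests on a few compounds, and the source may have more. Where it says the series, first, only, none or still open, it means among the compounds named here.

Working notes on the series. The shared core is seen in compound 1 `CC(C)(C)c1ccc(C(=O)/C=C/c2ccc([N+](=O)[O-])o2)cc1`, which carries tert-butyl on an aromatic carbon; compound 2 `O=C(/C=C/c1ccc([N+](=O)[O-])o1)c1ccc(-c2ccccc2)cc1` carries phenyl there and compound 3 `O=C(/C=C/c1ccc([N+](=O)[O-])o1)c1ccc(Br)cc1` bromo. In an ADME assay on Vero cells (Chlorocebus sabaeus) for cytotoxicity, read by resazurin assay, with a stated time of 72 h (a higher number here means that more compound is tolerated, a lower number that less compound is tolerated), compound 1 reaches only the limit > 100000 nM of the assay. In this assay compound 2 likewise stops at the limit > 100000 nM rather than a number. In this assay compound 3 also sits at the limit > 100000 nM and gives no number. Compound 3 thus stands where the other two stand, at the limit of > 100000 nM in this assay, at which 3 of the 3 values shown sit, and the steps a step that the two limits leave unreadable from compound 1 to compound 2, a step that the two limits leave unreadable from compound 1 to compound 3 and a step that the two limits leave unreadable from compound 2 to compound 3 are unreadable in size. Compound 4 `O=C(/C=C/c1ccc([N+](=O)[O-])o1)c1ccc(-n2ccnc2)cc1` differs from compound 3 by 1H-imidazol-1-yl in place of bromo on an aromatic carbon. The measured steps bear on this change only in that none of the three groups on the aromatic carbon pulled the value below the limit; no direction can be read from them. Compound 4 is therefore expected to remain at the limit in this assay. The step that the limit leaves unreadable from compound 3 to compound 4 that this estimate implies is expected to be none beyond the scatter. Compound 4 is estimated at 150000 nM, within a range from 60000 nM to 400000 nM.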

Compound 4, half-maximal cytotoxic concentration: > 100000 nM
Compound 4 gave a limit, no number; the forecaster's own chance of this, stated with the estimate: 80%; the middle value does not contradict the limit.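

In this assay, for the compounds shown here, compound 4 gives only a limit, > 100000 nM, so no step from compound 1, compound 2 or compound 3 to compound 4 can be read. The compounds shown leave open whether any of these four groups on the aromatic carbon changes the tolerated concentration: the limit of > 100000 nM in this assay, at which 4 of the 4 values shown sit.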